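Aryl substituent variation on the shared core: compound 4

The compounds below may be only part of what the source reports. "The series", "measured", "known", "first", "only" and "open" are said of these compounds alone.

Measured so far, in an assay on isolated protein for inhibition of Rho-associated protein kinase 2 (Homo sapiens), read by a luciferase reporter; a lower number here means a stronger inhibitor, a higher number a weaker inhibitor:
compound 1, `O=C(Nc1cc2cc[nH]c(=O)c2cc1Cl)C1CNCC1c1ccc(F)cc1`, gives 9 nM
compound 2, `O=C(Nc1cc2cc[nH]c(=O)c2cc1Cl)C1CNCC1c1ccccn1`, gives 14 nM
compound 3, `CC(C)(C)c1cccc(C2CNCC2C(=O)Nc2cc3cc[nH]c(=O)c3cc2Cl)c1`, gives 11 nM

All three numbers sit close together. From compound 1 the step to the pyridin-2-yl analogue is a 1.6-fold higher number from compound 1 to compound 2 (0.19 log units; within the scatter), and the step to the 3-(tert-butyl)phenyl analogue is a 1.2-fold higher number from compound 1 to compound 3 (0.09 log units; within the scatter). Between the latter two, a 1.3-fold lower number from compound 2 to compound 3 (0.10 log units; within the scatter). Compound 3 therefore stands among three values that are all within the scatter of one another; its nearest neighbour is compound 1 and its furthest is compound 2, and neither gap counts as a real difference.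

Compound 4, `CC(C)c1cccc(C2CNCC2C(=O)Nc2cc3cc[nH]c(=O)c3cc2Cl)c1`, differs from compound 3 only in the aryl group: hydrogen in place of methyl on a saturated chain carbon bound to an aromatic carbon and two saturated chain carbons. The measured steps that bear on this are the three aryl swaps above, each of which left this assay essentially unchanged even where the group changed more drastically than here. The expectation for compound 4 is accordingly no step beyond the scatter, a 1.1-fold higher number from compound 3 to compound 4 (0.04 log units; within the scatter). Compound 4 is estimated at 12 nM in this assay, with a range from 6 nM to 25 nM.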

Compound 4, half-maximal inhibitory concentration: 6 nM
Compound 4: middle estimate off by 2.0-fold (0.30 log units), on the high side; the range from low to high includes it.
By their numbers in this assay, from the lowest: compounds 4, 1, 3 and 2 (each within the scatter of the next, the first and the last beyond it).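

Working notes on the aryl group: in this assay, taking tert-butyl down to isopropyl, with hydrogen in place of methyl on a saturated chain carbon bound to an aromatic carbon and two saturated chain carbons, gives no real difference (a 1.8-fold lower number from compound 3 to compound 4 (0.26 log units; within the scatter)), so this methyl can go without a measurable consequence. The series now holds its first aryl swap beyond the scatter, a modest one (a 2.3-fold lower number from compound 2 to compound 4 (0.37 log units; beyond the scatter)), but the step to compound 4 from the 4-fluorophenyl analogue stays within it (a 1.5-fold lower number from compound 1 to compound 4 (0.18 log units; within the scatter)), and compound 3, which also carries an alkyl-substituted phenyl, remains within the scatter of compound 2, so this single pair does not make a trend across the aryl groups. No information is available that would explain these steps.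

Still open, from the compounds shown here alone, is whether the number holds if the isopropyl is cut further to ethyl or methyl, or if it is lengthened to a longer chain. Also open, going by these compounds, is how a charged or strongly hydrogen-bonding substituent on the phenyl ring, such as an amine or a carboxylic acid, would compare with the alkyl groups in compound 3 and compound 4.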